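Dropping One Methoxy From the Shared Core

A few compounds are considered here, and "the series" means these few. Any claim that something is new, unique, unknown or untested is made for them only; others in the source may bear on it.

In a functional assay on A2780 cells (Homo sapiens) for antiproliferative activity, read by MTT assay, with a stated time of 48 h (on this read-out lower numbers stand for stronger inhibition and higher numbers for weaker inhibition), the measured compounds are:
compound 1, `COc1ccc2c(/C=C/C(=O)c3cc(N)c(OC)c(OC)c3)c[nH]c2c1`, 204 nM
compound 2, `COc1ccc2c(/C=C/C(=O)c3cc(OC)c(OC)c(SC)c3)c[nH]c2c1`, 139 nM
compound 3, `COc1ccc2c(/C=C/C(=O)c3cc(OC)c(OC)c([Se]C)c3)c[nH]c2c1`, 65 nM

Compound 1 has the highest number of the three. Its nearest neighbour is compound 2, with a 1.5-fold lower number from compound 1 to compound 2 (0.17 log units; within the scatter); the furthest is compound 3, with a 3.1-fold lower number from compound 1 to compound 3 (0.50 log units; beyond the scatter).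

Compound 4 is `COc1cc(C(=O)/C=C/c2c[nH]c3ccccc23)cc(N)c1OC`. It differs from compound 1 at a single point: hydrogen in place of methoxy on an aromatic carbon. All three measured steps alter the other ring, so none of them bears on this change, and there is no direct guide to its size or direction. For compound 4, the expected outcome is a step of a 1.5-fold higher number from compound 1 to compound 4 (0.17 log units; within the scatter), most likely not beyond the scatter. The estimate for compound 4 in this assay is 300 nM, within a range of 100 nM to 900 nM.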

Compound 4, half-maximal inhibitory concentration: 351 nM
Beside the measured number, compound 4's estimate is 1.2-fold (0.07 log units) below it, within the range that was stated.
By their numbers in this assay, from the lowest: compound 3; then compounds 2, 1 and 4 (each within the scatter of the next, the first and the last beyond it).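

In this assay, going by these compounds alone, putting hydrogen in place of methoxy gives a 1.7-fold higher number from compound 1 to compound 4 (0.24 log units; within the scatter), the first reading of any change at this position on the shared core. Removing this methoxy therefore leaves the antiproliferative number within the scatter, so this position tolerates the loss of the group in this one compound pair. Nothing available explains this outcome. As far as these compounds go, whether a hydroxyl group, an ethoxy group or a fluorine atom would be tolerated here remains open. So does whether the same swap would behave alike in compound 2 or compound 3.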